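Replacing a sulfamide by an oxopiperazine on the aminomethyl side chain

The source may report more compounds than this note shows. Statements on the series, on what has been measured and on what is new or still open speak of the compounds shown alone.

In an assay on isolated protein for displacement of a labelled ligand from 5-hydroxytryptamine receptor 6 (Homo sapiens) (a lower number here means a stronger inhibitor, a higher number a weaker inhibitor), the two measured compounds share one saturated bicyclic core with a sulfonyl-linked aromatic ring. Compound 1 `NC[C@@H]1CCCc2cc(S(=O)(=O)c3cc[nH]c3)ccc21` gives 0.316 nM. Compound 2 `CNS(=O)(=O)NC[C@@H]1CCCc2cc(S(=O)(=O)c3cccc(F)c3)ccc21` gives 1 nM, the higher of the two numbers, and the gap to compound 1 lies beyond the usual scatter. For the measured compounds named here, no single-point step between measured compounds is available, so the effect of changing the side-chain terminus on this scaffold is untested. Compound 3 `O=C1CN(C[C@@H]2CCCc3cc(S(=O)(=O)c4cccc(F)c4)ccc32)CCN1` differs from compound 2 in one place: 3-oxopiperazin-1-yl in place of (methylsulfamoyl)amino on a saturated chain carbon bound to a saturated ring carbon. With no comparable step shown, a change of modest size in either direction is expected for this assay, and a result within the scatter of compound 2 cannot be ruled out. Compound 3 is therefore expected to give about 2 nM in this assay, between 0.5 nM and 8 nM, which corresponds to an expected step of a 2.0-fold higher number from compound 2 to compound 3 (0.30 log units; within the scatter).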

Compound 3, inhibition constant: 6.31 nM
Estimate against measurement, compound 3: 3.2-fold (0.50 log units) below, within the range that was stated.
By their numbers in this assay, from the lowest: compound 1; then compound 2; then compound 3.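

In this assay, swapping the group on this side chain gives a 6.3-fold higher number from compound 2 to compound 3 (0.80 log units; beyond the scatter) when 3-oxopiperazin-1-yl replaces (methylsulfamoyl)amino on a saturated chain carbon bound to a saturated ring carbon. For the compounds shown here, this is the first reading at this position, and it shows that the change in side-chain terminus weakens the inhibitor, although compound 3 with its six-membered non-aromatic ring still gives 6.31 nM in this assay. No measurement shown here accounts for the size of this step.

This single pair cannot separate the removal of the (methylsulfamoyl)amino group from the addition of the ring. Going by these compounds, it remains open how a simple piperazine without the carbonyl, a morpholine or an acetamide would compare at the same carbon, and whether the step would hold with the sulfonyl-linked aromatic ring of compound 1.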